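Chloro for Fluoro on the Ester-Bearing Ring

The compounds below may be only part of what the source reports. "The series", "measured", "known", "first", "only" and "open" are said of these compounds alone.

Compound 3 `COC(=O)c1cc(F)ccc1OC(=O)COc1cc(O)c2c(=O)cc(-c3ccccc3)oc2c1` gives 6820 nM in a functional assay on cells (T-cell, Mus musculus, strain BALB/c) for inhibition, read by MTT assay, with a stated time of 72 h (on this read-out higher numbers stand for weaker inhibition and lower numbers for stronger inhibition), the lowest number of the three measured. Compound 1 `COC(=O)c1cc(O)ccc1OC(=O)COc1cc(O)c2c(=O)cc(-c3ccccc3)oc2c1` gives 29500 nM and compound 2 `COC(=O)c1c(C)cccc1OC(=O)COc1cc(O)c2c(=O)cc(-c3ccccc3)oc2c1` gives 37200 nM, so compound 3 inhibits most strongly here, with a 4.3-fold lower number from compound 1 to compound 3 (0.64 log units; beyond the scatter) and a 5.5-fold lower number from compound 2 to compound 3 (0.74 log units; beyond the scatter) both beyond the scatter. Compound 4 `COC(=O)c1c(Cl)cccc1OC(=O)COc1cc(O)c2c(=O)cc(-c3ccccc3)oc2c1` differs from compound 3 by a group of 11 heavy atoms (8 carbon, 2 oxygen, 1 chlorine; one six-membered aromatic ring of carbon only) in place of a group of 11 heavy atoms (8 carbon, 2 oxygen, 1 fluorine; one six-membered aromatic ring of carbon only), on an oxygen next to a carbonyl group. For the measured compounds named here, no measured step swaps a fluorine for a chlorine; the nearest guide is compound 2, which carries a methyl group on the entering ring and gave 37200 nM, while a 1.3-fold higher number from compound 1 to compound 2 (0.10 log units; within the scatter) stayed within the scatter. A weakening of inhibition is therefore expected, a 2.2-fold higher number from compound 3 to compound 4 (0.34 log units; beyond the scatter), with wide uncertainty. Compound 4 is estimated at 15000 nM, likely between 5000 nM and 45000 nM.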

Compound 4, half-maximal inhibitory concentration: 38900 nM
The estimate for compound 4 lay 2.6-fold (0.41 log units) below the measured number; measured number inside the range.
By their numbers in this assay, from the lowest: compound 3; then compounds 1, 2 and 4 (each within the scatter of the next).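

On the oxygen next to a carbonyl group, the 3-chloro-2-(methoxycarbonyl)phenyl group does not keep the stronger inhibition of compound 3 in this assay (a 5.7-fold higher number from compound 3 to compound 4 (0.76 log units; beyond the scatter)). Chloro in place of methyl makes no readable difference (a 1.0-fold higher number from compound 2 to compound 4 (0.02 log units; within the scatter)), and the other comparison also stays within the scatter (a 1.3-fold higher number from compound 1 to compound 4 (0.12 log units; within the scatter)), so among these four only compound 3 stands apart. Nothing available explains why this change matters. The compounds shown leave open whether a bromo or methoxy group on this ring would match compound 3 or fall with compound 4.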